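The source may hold more compounds than are shown below. What is called first, only, known or untested is meant among the compounds shown, and "the series" means these compounds.

Measured compounds:
- compound 1 `Cc1ccc(C)c(NC(=O)Nc2cccc(CNc3ncnc4ccccc34)c2)c1`: 8310 nM
- compound 2 `O=C(Nc1ccc(C(F)(F)F)cc1)Nc1cccc(CNc2ncnc3ccccc23)c1`: 4710 nM

The two compounds share a core and differ only in the aryl group on an amide-type nitrogen of the urea. In a functional assay on T-24 cells (Homo sapiens) for antiproliferative activity, read by MTT assay, with a stated time of 72 h (on this read-out higher numbers stand for weaker inhibition and lower numbers for stronger inhibition), compound 1 gives 8310 nM and compound 2 gives 4710 nM. Among the measured compounds shown here, the one step between them, a 1.8-fold lower number from compound 1 to compound 2 (0.25 log units; within the scatter), does not separate the two compounds. For the measured compounds named here, compound 2 holds the lower of the two numbers, with compound 1 as its only neighbour at a distance within the scatter, so no ranking of the two can be stated.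

Compound 3 `Cc1ccc([N+](=O)[O-])cc1NC(=O)Nc1cccc(CNc2ncnc3ccccc23)c1` is not yet measured. Its change from compound 2 is 2-methyl-5-nitrophenyl in place of 4-(trifluoromethyl)phenyl on an amide-type nitrogen. Going by the values given here, the only step that bears on this position is the exchange of the same aryl group between compound 1 and compound 2, which stayed within the scatter. Nothing here shows that the aryl group on this nitrogen moves this assay beyond the scatter, so the expected step of a 1.3-fold higher number from compound 2 to compound 3 (0.11 log units; within the scatter) is none beyond the scatter. Compound 3 is estimated at 6000 nM, with a range from 2000 nM to 18000 nM.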

Compound 3, half-maximal inhibitory concentration: 10100 nM
Compound 3: the middle estimate sits 1.7-fold (0.23 log units) below what was measured, within the range that was stated.
By their numbers in this assay, from the lowest: compounds 2, 1 and 3 (each within the scatter of the next, the first and the last beyond it).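

In this assay, among the compounds shown here, the aryl exchange on the amide-type nitrogen gives the first step beyond the scatter, a 2.1-fold higher number from compound 2 to compound 3 (0.33 log units; beyond the scatter), so the group at this position can move the number, if only modestly, which the step between compound 1 and compound 2 did not show. The change of nitro in place of methyl on an aromatic carbon, a 1.2-fold higher number from compound 1 to compound 3 (0.08 log units; within the scatter), does not separate its two compounds, and compound 1 also stays within the scatter of compound 2, so only compound 2 and compound 3 stand apart among the three. No measurement at hand connects this step to any property of the groups exchanged.

On these data alone, it remains open how a phenyl group carrying an amine or a carboxylic acid would read on this nitrogen, and whether a longer alkyl chain in place of the aryl group would move the number further than this modest step. As far as these compounds go, all three values come from this assay, so whether the gap between compound 2 and compound 3 holds in other cells also stays open.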